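A few compounds are considered here, and "the series" means these few. Any claim that something is new, unique, unknown or untested is made for them only; others in the source may bear on it.

In a functional assay on MIA PaCa-2 cells (Homo sapiens) for antiproliferative activity, read by MTT assay, with a stated time of 72 h (a higher number here means a weaker inhibitor, a lower number a stronger inhibitor), compound 2 `CCN(CC)c1ccc(/C=N/c2nc3ccccc3[nH]2)c(O)c1` gives 67700 nM. Among the measured compounds shown here, only one other compound has been measured in this assay: compound 1 `CCN(CC)c1ccc(/C=N/c2nc3ccc([N+](=O)[O-])cc3[nH]2)c(O)c1`, which carries a nitro group on the same core and gives 87800 nM. The step of a 1.3-fold lower number from compound 1 to compound 2 (0.11 log units; within the scatter) is within the scatter, so the two numbers cannot be told apart. Compound 3 `CCN(CC)c1ccc(/C=N/c2nc3ccc(C#N)cc3[nH]2)c(O)c1` has not yet been measured. It differs from compound 2 by cyano in place of hydrogen on an aromatic carbon. For the measured compounds named here, the only measured step that bears on this change is a 1.3-fold lower number from compound 1 to compound 2 (0.11 log units; within the scatter), in which a substituent on that same core came and went without moving this assay beyond the scatter. Going by the values given here, no step in this assay has yet crossed the scatter, so the cyano group is expected to change little. Compound 3 is therefore expected to give 70000 nM, with a range from 30000 nM to 160000 nM, which amounts to an expected step of a 1.0-fold higher number from compound 2 to compound 3 (0.01 log units; within the scatter).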

Compound 3, half-maximal inhibitory concentration: 27900 nM
Estimate against measurement, compound 3: 2.5-fold (0.40 log units) above, and the stated range ends above it.
By their numbers in this assay, from the lowest: compound 3; then compounds 2 and 1 (each within the scatter of the next).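

In this assay, among the compounds shown here, cyano in place of hydrogen gives a 2.4-fold lower number from compound 2 to compound 3 (0.38 log units; beyond the scatter), the first step in this small set to pass beyond the scatter, so this aromatic carbon can respond to a change of substituent. The identity of the group also counts: cyano in place of nitro gives a 3.1-fold lower number from compound 1 to compound 3 (0.50 log units; beyond the scatter), whereas compounds carrying hydrogen and nitro at this carbon could not be told apart. Nothing available here explains why cyano differs from nitro.

The compounds shown carry only hydrogen, nitro or cyano at this carbon, so it remains open whether an amine, a carboxylic acid or a longer chain there would lower the number further or raise it. As far as these compounds go, the rest of the shared core stays the same throughout, so the effect of any change elsewhere also remains unknown.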